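Bromine Added Where Both Known Compounds Sit at the Limit

The compounds below may be only part of what the source reports. "The series", "measured", "known", "first", "only" and "open" are said of these compounds alone.

In a functional assay on isolated protein for antagonist activity at adenosine receptor A2b (Homo sapiens) (a lower number here means a stronger inhibitor, a higher number a weaker inhibitor), compound 1 `O=c1oc2c(O)cccc2cc1-c1cccs1` reaches only the limit of the assay, > 30000 nM. Compound 2 `O=c1oc2c(O)c(O)ccc2cc1-c1cccs1` likewise shows only a limit in this assay, > 30000 nM. The step that the two limits leave unreadable from compound 1 to compound 2 therefore cannot be read, since the limit of > 30000 nM in this assay, at which 2 of the 2 values shown sit, holds both values. Compound 3 `O=c1oc2c(O)c(O)ccc2cc1-c1cc(Br)cs1` differs from compound 2 by bromo in place of hydrogen on an aromatic carbon. Among the compounds with values here, no measured step bears on this change, and with both known compounds at the limit, the expected step that the limit leaves unreadable from compound 2 to compound 3 cannot be placed beyond the scatter. Compound 3 is therefore estimated at 50000 nM in this assay, between 15000 nM and 200000 nM, most probably again reported only as a limit.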

Compound 3, inhibition constant: > 30000 nM
Compound 3: no number, only a limit; the forecaster's own chance of this, stated with the estimate: 80%; the middle value does not contradict the limit.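

Within the data shown here, no step from compound 2 to compound 3 can be read, since both give only a limit rather than a number: the limit of > 30000 nM in this assay, at which 3 of the 3 values shown sit.

The compounds shown leave open how strongly any of them acts in this assay and whether bromo changes that at all.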